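Dropping the chain phenyl of compound 1

The source may hold more compounds than are shown below. What is called first, only, known or untested is meant among the compounds shown, and "the series" means these compounds.

Two compounds have been measured in an assay on membranes from lung (Cavia porcellus) for binding affinity to cysteinyl leukotriene receptor (Homo sapiens); on this read-out higher numbers stand for weaker inhibition and lower numbers for stronger inhibition:
compound 1 `O=C(O)CCC(Cc1ccc(OCc2ccc3ccccc3n2)cc1)c1ccccc1`, 31 nM
compound 2 `O=C(O)CCC(Cc1cccc(OCc2ccc3ccccc3n2)c1)c1ccccc1`, 52 nM

Compound 1 gives the lowest of the two numbers, and compound 2 is the nearest to it; the gap between them lies within the usual scatter, so the two values cannot be told apart. Compound 3 `O=C(O)CCCCc1ccc(OCc2ccc3ccccc3n2)cc1` is still to be measured. It derives from compound 1 by one change: hydrogen in place of phenyl on a saturated chain carbon bound to two saturated chain carbons. For the measured compounds named here, no measured pair shows a step of this kind, so its size can only be guessed. Going by the values given here, since the phenyl on the saturated chain carbon is the only part of compound 1 taken away and the shared core is left untouched, a loss in this assay beyond the scatter is expected rather than a gain. For compound 3 the estimate in this assay is 100 nM, with a range from 30 nM to 350 nM, which means an expected step of a 3.2-fold higher number from compound 1 to compound 3 (0.51 log units; beyond the scatter).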

Compound 3, inhibition constant: 110 nM
Beside the measured number, compound 3's estimate is 1.1-fold (0.04 log units) below it; the range from low to high includes it.
By their numbers in this assay, from the lowest: compounds 1 and 2 (each within the scatter of the next); then compound 3.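

Replacing the phenyl with hydrogen on the saturated chain carbon bound to two saturated chain carbons gives, in this assay, a 3.5-fold higher number from compound 1 to compound 3 (0.55 log units; beyond the scatter). For the compounds shown here, this is the first step read at this position, and it shows that the phenyl contributes to the binding affinity measured here, although the loss is modest and compound 3 still gives 110 nM without it. Nothing shown here gives a reason for the size of this step.

As far as these compounds go, whether the phenyl itself is needed or any group on this carbon would do stays open, since a methyl, a cyclohexyl or a benzyl at the same place would separate those two readings. Also open, from the compounds shown here alone, is whether the same change would cost as much when made on compound 2.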